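A side chain swap on compound 2

A few compounds are considered here, and "the series" means these few. Any claim that something is new, unique, unknown or untested is made for them only; others in the source may bear on it.

Compound 1 `NCCCCCCC(=O)Nc1nc2ccc(C(=O)c3ccccc3)cc2[nH]1`: > 30000 nM, a limit
Compound 2 `CC(C)Cn1c(N)nc2ccc(C(=O)c3ccccc3)cc21`: > 30000 nM, a limit

Both entries come from an ADME assay on CRL8155 cells (Homo sapiens) for cytotoxicity, read by resazurin assay, with a stated time of 72 h; on this read-out lower numbers stand for an effect already at smaller amounts and higher numbers for an effect only at larger amounts of compound. Compound 2 stands at > 30000 nM, which is a limit and not a number. This is the limit of > 30000 nM in this assay, at which 2 of the 2 values shown sit. Compound 3 `Nc1nc2ccc(C(=O)c3ccccc3)cc2n1CCN1CCCCC1` differs from compound 2 by (piperidin-1-yl)methyl in place of isopropyl on a saturated chain carbon bound to an aromatic nitrogen; cut one bond further out, this reads isobutyl to 2-(piperidin-1-yl)ethyl. Within the data shown here, no measured step shows what such a change does in this assay, so little or no change beyond the scatter is expected, with any shift towards lower numbers. The expected change is a number no higher from compound 2 to compound 3 (the limit leaves the size open). For compound 3 the estimated value is 30000 nM, with an expected range from 12000 nM to 60000 nM.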

Compound 3, half-maximal effective concentration: > 30000 nM
Compound 3: no number, only a limit; the forecaster's own chance of this, stated with the estimate: 60%; the middle value lies on the limit itself.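

No step can be read from compound 2 to compound 3, since each gives only a limit and not a number: the limit of > 30000 nM in this assay, at which 3 of the 3 values shown sit.

The compounds shown leave open at what concentration, if any, compound 1, compound 2 or compound 3 would harm these cells.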